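The source may report more compounds than this note shows. Statements on the series, on what has been measured and on what is new or still open speak of the compounds shown alone.

Working notes on the series. Compound 1 `O=C(NCCCO)C(c1ccccc1)c1ccccc1` gives 1000000 nM in an assay for inhibition of Deoxyuridine 5'-triphosphate nucleotidohydrolase, mitochondrial (Homo sapiens), read by spectrophotometry; a lower number here means a stronger inhibitor, a higher number a weaker inhibitor. Compound 3 `O=C(O)CCCn1ccc(=O)[nH]c1=O` gives 1000000 nM in this assay; at the digits shown it is level with compound 1, the two sharing the highest number of the three and lying within the scatter of each other. Compound 2 `O=c1ccn(CCCCOC(c2ccccc2)c2ccccc2)c(=O)[nH]1` gives 49000 nM in this assay, a lower number than either, and the gap to compound 1 lies beyond the scatter. Among the measured compounds shown here, no pair of measured compounds differs in one place, so no step within the measured set can be read as a single structural change.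

Compound 4 `O=C(NCCCO)C(c1ccccc1)(c1ccccc1)c1ccccc1` has not yet been measured in this assay. It differs from compound 1 by phenyl in place of hydrogen on a saturated chain carbon bound to two aromatic carbons and a carbonyl carbon. Nothing in the measured set shows what adding a phenyl at such a position does; the only contrast available, between compound 1 and compound 2, changes several things at once and gives no guide to this single change. The expectation is therefore that the step of a 1.3-fold lower number from compound 1 to compound 4 (0.10 log units; within the scatter) lies within the scatter, or is small in either direction. Compound 4 is estimated at 800000 nM in this assay, with a range from 200000 nM to 1000000 nM.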

Compound 4, inhibition constant: 1000000 nM
The estimate for compound 4 lay 1.3-fold (0.10 log units) below the measured number; low and high end bracket the measured number.
By their numbers in this assay, from the lowest: compound 2; then compounds 1, 3 and 4 (each within the scatter of the next).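

In this assay, among the compounds shown here, phenyl in place of hydrogen on a saturated chain carbon bound to two aromatic carbons and a carbonyl carbon gives no change at the digits printed from compound 1 to compound 4 (within the scatter), the first single change that can be read. Compound 4 and compound 1 are therefore level, and this one change opens no gap at this position, although both compounds lie at the highest number seen so far, so the reading comes from the weak end of the series. No measurement at hand offers an explanation for this result.

On these data alone, whether a different group on this carbon, such as a methyl, an amine or a carboxylic acid, would give a number beyond the scatter of compound 1 remains open. Also open, as far as these compounds go, is whether the same phenyl would still make no difference if the chain of compound 1 ending in a hydroxyl were replaced by a longer chain or by one ending in an amine.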